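The source may hold more compounds than are shown below. What is called first, only, known or untested is meant among the compounds shown, and "the series" means these compounds.

Series notes. Compound 1 `O=c1[nH]c(=O)n([C@H]2C[C@H](O)[C@@H](CO)O2)cc1C#CCCCCCCCCCF` and compound 2 `O=c1[nH]c(=O)n([C@H]2C[C@H](O)[C@@H](CO)O2)cc1C#CCCCCCCCCCCl` share one core; compound 3 `O=c1nc2oc(CCCCCCCCCF)cc2cn1[C@H]1C[C@H](O)[C@@H](CO)O1` and compound 4 `O=c1nc2oc(CCCCCCCCCCl)cc2cn1[C@H]1C[C@H](O)[C@@H](CO)O1` share another, and compound 3 and compound 1 have the same atoms joined differently, so the difference between the two cores is not broken down here.

In a functional assay for cytotoxicity, read by microscopy (on this read-out higher numbers stand for lower toxicity in this test and lower numbers for higher toxicity in this test), compound 1 gives 200000 nM. In this assay compound 2 gives 200000 nM. The change between them is chloro in place of fluoro on a saturated chain carbon, nine bonds along the chain from a triple-bonded carbon, and it moves the read-out by no change at the digits printed from compound 1 to compound 2 (within the scatter). For compound 3 this assay reports only a limit, > 50000 nM, as noted in the limit of > 50000 nM in this assay, at which 1 of the 3 values shown sits.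

The change from compound 3 to compound 4 is chloro in place of fluoro on a saturated chain carbon, nine bonds along the chain from an aromatic carbon. It is the same kind of change as that from compound 1 to compound 2, though the place differs: nine bonds along the chain from an aromatic carbon in compound 4 against nine bonds along the chain from a triple-bonded carbon in compound 2. Since compound 1 to compound 2 gave no change at the digits printed from compound 1 to compound 2 (within the scatter), the step to compound 4 is expected to be a step that the limit leaves unreadable from compound 3 to compound 4 in this assay, beside that earlier one. Compound 4 is therefore estimated at 100000 nM, between 50000 nM and 200000 nM, with a limit rather than a number quite likely.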

Compound 4, minimum cytotoxic concentration: > 200000 nM
Compound 4: a limit, no number; the forecaster's own chance of this, stated with the estimate: 70%; middle value at least 2.0-fold (0.30 log units) away from the limit.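

In this assay compound 3 gives only a limit, > 50000 nM. Compound 4 also gives only a limit, > 200000 nM, so no size can be read for the step between this pair. Left open is whether chloro in place of fluoro on a saturated chain carbon, nine bonds along the chain from an aromatic carbon, moves the read-out in this assay at all.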